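From naphthalen-1-yl to 4-chlorophenyl on compound 1

The source may hold more compounds than are shown below. What is called first, only, known or untested is meant among the compounds shown, and "the series" means these compounds.

Compound 1 (`CCCCCCn1cc(COc2ccc(-c3cc(-c4cccc5ccccc45)nc(N)n3)c(O)c2)nn1`) stands without a number: in an ADME assay on cells (Macrophage) for cytotoxicity, read by resazurin assay, with a stated time of 48 h (a lower number here means that less compound is tolerated, a higher number that more compound is tolerated), compound 1 gives "not determined" (no result reported) as its entry. Compound 2 (`CC(C)c1ccc(-c2cc(-c3ccc(OCc4cn(Cc5ccc(Br)cc5)nn4)cc3O)nc(N)n2)cc1`) shows the same gap, with "not determined" (no result reported) as its entry. Only compound 3 (`Nc1nc(-c2ccc(OCc3cn(Cc4ccccc4)nn3)cc2O)cc(-c2cccc3ccccc23)n1`) has a number, 71300 nM as a single reading. Compound 4 (`CCCCCCn1cc(COc2ccc(-c3cc(-c4ccc(Cl)cc4)nc(N)n3)c(O)c2)nn1`) keeps the core of compound 1 and puts 4-chlorophenyl in place of naphthalen-1-yl on an aromatic carbon. Among the measured compounds shown here, no measured pair in this assay shows what such a swap does, so the expected step is none beyond the scatter, with compound 3 at 71300 nM as the only guide. Compound 4 is expected at 50000 nM within an estimated range from 15000 nM to 150000 nM around that middle.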

Compound 4, half-maximal cytotoxic concentration: 30300 nM
Estimate against measurement, compound 4: 1.7-fold (0.22 log units) above, within the range that was stated.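

Compound 1 carries no single number, so no step to compound 4 can be read, and no evidence at hand explains the result. Going by these compounds, what replacing naphthalen-1-yl with 4-chlorophenyl does on the shared core remains open.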